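A few compounds are considered here, and "the series" means these few. Any claim that something is new, unique, unknown or untested is made for them only; others in the source may bear on it.

Compound 1 `N#Cc1ccc(Nc2nc(Oc3ccnc4ccccc34)nc(N3CCN(c4ncccn4)CC3)n2)cc1C(F)(F)F` joins a shared core to a (quinolin-4-yl)oxy group, an anilino group bearing a nitrile and a trifluoromethyl, and a 4-(pyrimidin-2-yl)piperazin-1-yl group. In a functional assay on DU-145 cells (Homo sapiens) for cytotoxicity, read by sulforhodamine B assay, with a stated time of 48 h (on this read-out lower numbers stand for stronger inhibition of growth and higher numbers for weaker inhibition of growth), compound 1 gives only a limit of > 100000 nM, so where it truly stands is not known. Compound 2 `N#Cc1ccc(Nc2nc(Oc3ccnc4ccccc34)nc(N3CCN(c4cccc(Cl)c4Cl)CC3)n2)cc1C(F)(F)F` swaps the pyrimidin-2-yl for a 2,3-dichlorophenyl, and in this assay compound 2 also gives only a limit of > 100000 nM. The step that the two limits leave unreadable from compound 1 to compound 2 cannot be read, since (the limit of > 100000 nM in this assay, at which 2 of the 2 values shown sit). Compound 3 `CC1CC(C)CN(c2nc(Nc3ccc(C#N)c(C(F)(F)F)c3)nc(Oc3ccnc4ccccc34)n2)C1` differs from compound 1 by 3,5-dimethylpiperidin-1-yl in place of 4-(pyrimidin-2-yl)piperazin-1-yl on an aromatic carbon. For the measured compounds named here, no measured step covers this kind of change, and both measured neighbours rest at a limit. The step of a number no higher from compound 1 to compound 3 (the limit leaves the size open) is therefore expected to be small. Compound 3 is estimated at 100000 nM, from 20000 nM to 300000 nM, most likely again as a limit.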

Compound 3, concentration for total growth inhibition: 68000 nM
Compound 3: the middle estimate sits 1.5-fold (0.17 log units) above what was measured; low and high end bracket the measured number.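

For the compounds shown here, compound 3 is the first compound here to give a number rather than a limit in this assay, so a group at this position on the shared core can bring the read-out within measurable range. Putting 3,5-dimethylpiperidin-1-yl in place of 4-(pyrimidin-2-yl)piperazin-1-yl gives an at least 1.4-fold lower number from compound 1 to compound 3 (0.16 log units; that floor lies within the scatter). This is only a floor, and its true size stays unknown because compound 1 and compound 2 rest at a limit, so neither step from them can be read fully: the limit of > 100000 nM in this assay, at which 2 of the 3 values shown sit.

The compounds shown cannot separate the part played by the two methyl groups from the loss of the pyrimidin-2-yl ring. Going by these compounds, how a plain piperidin-1-yl, a morpholin-4-yl or an open-chain amine would read at this position remains open.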